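Adding a Methoxy Group to Compound 3

The source may hold more compounds than are shown below. What is called first, only, known or untested is meant among the compounds shown, and "the series" means these compounds.

Compound 1 (`C=C(Br)C(=O)Nc1ccc(/C=C/C(=O)c2ccc(Cl)cc2)cc1`) gives 810 nM in a functional assay on MOLT-4 cells (Homo sapiens) for antiproliferative activity, with a stated time of 48 h (on this read-out lower numbers stand for stronger inhibition and higher numbers for weaker inhibition), and compound 2 (`C=C(Br)C(=O)Nc1ccc(/C=C/C(=O)c2ccc(Cl)c(Cl)c2)cc1`) gives 1800 nM on the same test. Compound 3 (`C=C(Br)C(=O)Nc1ccc(C(=O)/C=C/c2ccccc2)cc1`) at 500 nM sits within the scatter of compound 1 and clearly lower than compound 2. Compound 4 (`C=C(Br)C(=O)Nc1ccc(C(=O)/C=C/c2ccccc2OC)cc1`) carries methoxy in place of hydrogen on an aromatic carbon, ortho to a large group (methoxy in place of hydrogen on an aromatic carbon). Among the compounds with values here, the only comparable measured step is chloro in place of hydrogen on an aromatic carbon (a 2.2-fold higher number from compound 1 to compound 2 (0.35 log units; beyond the scatter)). It involves a different group, so it is a weak guide, but it points to a modest rise rather than a large shift. In this assay the expected step is small and towards weaker inhibition (a 1.4-fold higher number from compound 3 to compound 4 (0.15 log units; within the scatter)). For compound 4 the estimated value is 700 nM (expected range 250 nM to 2000 nM).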

Compound 4, half-maximal inhibitory concentration: 240 nM
For compound 4 the middle estimate is 2.9-fold (0.46 log units) above the measured one; measured number below the stated range.
By their numbers in this assay, from the lowest: compound 4; then compounds 3 and 1 (each within the scatter of the next); then compound 2.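

Replacing hydrogen with methoxy on an aromatic carbon, ortho to a large group, gives a 2.1-fold lower number from compound 3 to compound 4 (0.32 log units; beyond the scatter) in this assay and so moves towards stronger inhibition. Within the data shown here, the only earlier step, adding chloro to a different compound and a different place, gives a 2.2-fold higher number from compound 1 to compound 2 (0.35 log units; beyond the scatter) and runs the other way, so adding a group to an aromatic carbon has no single direction across these compounds. No supporting measurement explains the change.

On these data alone, it remains open whether this result is specific to methoxy. A hydroxyl or ethoxy group at the same place could help answer that.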